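Amide tail swap on the shared core: kinetic solubility outlook

This account rests on a few compounds, and the source may have more. Where it says the series, first, only, none or still open, it means among the compounds named here.

Two members of the series have numbers in a physicochemical assay for solubility, read by spectrophotometry, measured as kinetic solubility, at pH 8, tested at 500 uM; a lower number here means a less soluble compound, a higher number a more soluble compound. Compound 1 `CN1CCC(NS(=O)(=O)c2ccccc2Nc2cc(-c3ccc4ccn(C)c4c3)c3nccnc3c2)C1` gives 26 ug/mL. Compound 2 `CN1CCC(NC(=O)c2ccncc2Nc2cc(-c3ccc4ccn(C)c4c3)c3nccnc3c2)CC1` gives 246 ug/mL, the highest of the two numbers seen so far; compound 1 lies a long way under it, well beyond the scatter. The two compounds differ in more than one place, so no single structural step can be read from that gap; the pair shows only that the series spans a wide range in this assay.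

Compound 3 `CC(=O)N1CC(CNC(=O)c2ccncc2Nc2cc(-c3ccc4ccn(C)c4c3)c3nccnc3c2)C1` has not been measured. It differs from compound 2 in one place: (1-acetylazetidin-3-yl)methyl in place of 1-methylpiperidin-4-yl on an amide-type nitrogen. Nothing measured in the series isolates this change, so the expectation rests on the standing of compound 2 alone and carries wide uncertainty. The step from compound 2 to compound 3 is expected to be a decrease, a 2.7-fold lower number from compound 2 to compound 3 (0.44 log units; beyond the scatter), of a size that may exceed the scatter but should leave compound 3 above the level of compound 1. In this assay compound 3 is therefore expected to give about 90 ug/mL, within a range of 25 ug/mL to 250 ug/mL.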

Compound 3, solubility: 252 ug/mL
Beside the measured number, compound 3's estimate is 2.8-fold (0.45 log units) below it; the whole stated range lies below it.
By their numbers in this assay, from the lowest: compound 1; then compounds 2 and 3 (each within the scatter of the next).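

Working notes on the amide nitrogen position: in this assay, (1-acetylazetidin-3-yl)methyl in place of 1-methylpiperidin-4-yl on an amide-type nitrogen gives a 1.0-fold higher number from compound 2 to compound 3 (0.01 log units; within the scatter), the first single-place step readable in the series. Within the scatter, this assay does not separate the two groups, even though the step exchanges a six-membered ring for a four-membered ring and brings in a double bond outside aromatic rings, with no difference in the counted hydrogen-bond donors, hydrogen-bond acceptors or net charge. No available data explain why these two groups read alike.

This single step does not show whether the same match would hold for other groups on this nitrogen, such as a morpholine ring, a carboxylic acid, a primary amine or a longer chain, or for the azetidine without its acetyl group. Compound 1 differs from compound 2 and compound 3 in more than one place, so what separates it from them in this assay remains unresolved, and no single structural feature can yet be tied to its number.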